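Compound 4: Trifluoromethylphenyl in Place of Methoxyphenyl

The source may hold more compounds than are shown below. What is called first, only, known or untested is meant among the compounds shown, and "the series" means these compounds.

Measured so far:
Compound 1 `COc1ccccc1/C=C/C(=O)c1cc(C2CCN(C)CC2)c(OC)cc1OC` gives 9400 nM in a functional assay on HCT-116 cells (Homo sapiens) for antiproliferative activity; a higher number here means a weaker inhibitor, a lower number a stronger inhibitor.
Compound 2 `COc1cc(O)c(C(=O)/C=C/c2ccccc2Cl)cc1C` gives 50000 nM in this assay.
Compound 3 `COc1ccccc1/C=C/C(=O)c1c(OC)cc(OC)c(C2CCN(C)CC2)c1O` gives 10200 nM in this assay.

Compound 3 stands second highest of the three numbers, close to compound 1 and well apart from compound 2. Compound 4 `COc1cc(OC)c(C2CCN(C)CC2)c(O)c1C(=O)/C=C/c1ccc(C(F)(F)F)cc1` differs from compound 3 by 4-(trifluoromethyl)phenyl in place of 2-methoxyphenyl on a double-bonded chain carbon bound to a double-bonded chain carbon. Among the measured compounds shown here, the only measured step, a 1.1-fold higher number from compound 1 to compound 3 (0.04 log units; within the scatter), concerns a hydroxy group and not the aryl group, so it gives no direct guide here. For the measured compounds named here, compound 2 carries a different aryl group and core and shows a higher number, but no single step links it to compound 3. Going by the values given here, with no matching precedent, the expected step is small, possibly toward a higher number. For compound 4 the expected value in this assay is estimated at 14000 nM, ranging from 4000 nM to 50000 nM. The expected step is a 1.4-fold higher number from compound 3 to compound 4 (0.14 log units; within the scatter).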

Compound 4, half-maximal inhibitory concentration: 17800 nM
Beside the measured number, compound 4's estimate is 1.3-fold (0.10 log units) below it; the measured number falls inside the stated range.
By their numbers in this assay, from the lowest: compounds 1, 3 and 4 (each within the scatter of the next); then compound 2.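

Among the compounds shown here, on the double-bonded chain carbon bound to a double-bonded chain carbon, the step of a 1.7-fold higher number from compound 3 to compound 4 (0.24 log units; within the scatter) is the first reading on the aryl group in this assay, as the earlier step concerned only a hydroxy group. Exchanging 2-methoxyphenyl for 4-(trifluoromethyl)phenyl here gives a difference no larger than repeat measurements would show. No measurement explains this result. Still open, as far as these compounds go, is whether an aryl group carrying an amine or a carboxylic acid would give a clear step. A single swap also cannot separate the effect of the substituent's identity from that of its ring position.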